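A few compounds are considered here, and "the series" means these few. Any claim that something is new, unique, unknown or untested is made for them only; others in the source may bear on it.

Working notes on the series, all read in a functional assay on THP-1 cells (Homo sapiens) for inhibition, read by ELISA, with stated times of 1 h and 18 h; a higher number here means a weaker inhibitor, a lower number a stronger inhibitor. On the shared core, compound 1 `NC(=O)[C@@H]1[C@H](Nc2nc(Nc3cccc(C(=O)N4CCCC4)c3)ncc2-c2cccnc2)[C@H]2C=C[C@@H]1C2`, with pyridin-3-yl, gives 320 nM. Compound 2 `NC(=O)[C@@H]1[C@H](Nc2nc(Nc3cccc(C(=O)N4CCCC4)c3)ncc2C2CC2)[C@H]2C=C[C@@H]1C2`, with cyclopropyl, gives 90 nM. Compound 3 `NC(=O)[C@@H]1[C@H](Nc2nc(Nc3cccc(C(=O)N4CCCC4)c3)ncc2-c2ccccc2F)[C@H]2C=C[C@@H]1C2`, with 2-fluorophenyl, gives 130 nM. Its standing rests on two steps: a 1.4-fold higher number from compound 2 to compound 3 (0.16 log units; within the scatter), and a 2.5-fold lower number from compound 1 to compound 3 (0.39 log units; beyond the scatter). The remaining step is a 3.6-fold lower number from compound 1 to compound 2 (0.55 log units; beyond the scatter).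

Compound 4 `NC(=O)[C@@H]1[C@H](Nc2nc(Nc3cccc(C(=O)N4CCCC4)c3)ncc2-c2cccc(F)c2)[C@H]2C=C[C@@H]1C2` is next: 3-fluorophenyl in place of 2-fluorophenyl on an aromatic carbon, with 3-fluorophenyl in place of 2-fluorophenyl on an aromatic carbon. Going by the values given here, no measured step moves the fluorine around the phenyl ring, so the evidence is indirect. The three steps above exchange whole groups, and the largest of them, a 3.6-fold lower number from compound 1 to compound 2 (0.55 log units; beyond the scatter), is only modest. A shift of one fluorine is therefore not expected to produce a step beyond the scatter in this assay, and no direction is favoured with any confidence. The expected step is a 1.2-fold higher number from compound 3 to compound 4 (0.06 log units; within the scatter). For compound 4 the estimated value is 150 nM, with an expected range of 70 nM to 320 nM.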

Compound 4, half-maximal inhibitory concentration: 870 nM
Beside the measured number, compound 4's estimate is 5.8-fold (0.76 log units) below it; the measured number lies above the stated range.
By their numbers in this assay, from the lowest: compounds 2 and 3 (each within the scatter of the next); then compound 1; then compound 4.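

In this assay, moving only the fluorine on the phenyl group, with the heavy atoms and counted hydrogen-bond donors and acceptors unchanged, gives a 6.7-fold higher number from compound 3 to compound 4 (0.83 log units; beyond the scatter), so this place, ortho to a large group and para to a large group, distinguishes between the two fluorophenyl isomers. The fluorophenyl groups therefore cannot be treated as one class here: 2-fluorophenyl stays within the scatter of cyclopropyl, whereas 3-fluorophenyl gives a 9.7-fold higher number from compound 2 to compound 4 (0.99 log units; beyond the scatter) and also a 2.7-fold higher number from compound 1 to compound 4 (0.43 log units; beyond the scatter), leaving compound 4 with the highest number of the four. Nothing measured here accounts for this dependence on the fluorine's position.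

The compounds shown leave open whether the higher number follows fluorine specifically or any group at that place on the phenyl ring. Unsubstituted phenyl, 4-fluorophenyl, 3-chlorophenyl and 3-methoxyphenyl would help separate these readings.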